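This account rests on a few compounds, and the source may have more. Where it says the series, first, only, none or still open, it means among the compounds named here.

Measured compounds:
compound 1 `COc1cc(-c2noc(N)c2-c2ccc(Cl)cc2)cc(OC)c1OC`, which in a functional assay on A549 cells (Homo sapiens) for cytotoxicity, read by MTT assay, with a stated time of 48 h (a lower number here means a stronger inhibitor, a higher number a weaker inhibitor), sits at a limit of the assay, > 50000 nM
compound 2 `COc1ccc(-c2c(-c3cc(OC)c(OC)c(OC)c3)noc2NC(C)=O)cc1`, 10700 nM
compound 3 `COc1cc(-c2noc(NC(C)=O)c2-c2ccc(Cl)cc2)cc(OC)c1OC`, 25000 nM

Compound 3 carries acetyl in place of hydrogen on a nitrogen on an aromatic ring relative to compound 1, and that step is an at least 2.0-fold lower number from compound 1 to compound 3 (0.30 log units; that floor lies within the scatter); the value of compound 1 is a limit (the limit of > 50000 nM in this assay, at which 1 of the 3 values shown sits). Compound 2 and compound 3 differ by a 2.3-fold higher number from compound 2 to compound 3 (0.37 log units; beyond the scatter). How the cores of compound 2 and compound 1 differ is not broken down here.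

Compound 4 `COc1ccc(-c2c(-c3cc(OC)c(OC)c(OC)c3)noc2N(C(C)=O)C(C)=O)cc1` is not yet measured. It carries acetyl in place of hydrogen on an amide-type nitrogen relative to compound 2. Among the measured compounds shown here, this is the same kind of change as the one from compound 1 to compound 3, but not the same: there the acetyl enters on a nitrogen on an aromatic ring whose other neighbours are an aromatic carbon, here on an amide-type nitrogen whose other neighbours are an aromatic carbon and a carbonyl carbon. Resting on the measured step of an at least 2.0-fold lower number from compound 1 to compound 3 (0.30 log units; that floor lies within the scatter) from compound 1, the step from compound 2 to compound 4 is expected to be a 1.3-fold lower number from compound 2 to compound 4 (0.13 log units; within the scatter). Compound 4 is therefore estimated at 8000 nM in this assay, between 3000 nM and 30000 nM.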

Compound 4, half-maximal inhibitory concentration: 430 nM
Estimate against measurement, compound 4: 19-fold (1.27 log units) above; the whole stated range lies above it.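

In this assay, putting an acetyl on the amide-type nitrogen gives a 25-fold lower number from compound 2 to compound 4 (1.40 log units; beyond the scatter), a large step on this core. Set beside the earlier acetyl step, which was on a different kind of nitrogen and a different core, the comparison stays unsettled: the same change on two cores in this assay, an at least 2.0-fold lower number (0.30 log units; that floor lies within the scatter) from compound 1 to compound 3 and a 25-fold lower number (1.40 log units; beyond the scatter) from compound 2 to compound 4; the limit leaves it open whether they differ The value of compound 1 is a limit, > 50000 nM, so these pairs show a large step on one core but do not show whether its size carries over to another.

The compounds shown leave open what diacetylamino would give on the core of compound 3. They also leave open whether a different group on that nitrogen, such as propionyl or methyl, would give a step of similar size.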